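The source may report more compounds than this note shows. Statements on the series, on what has been measured and on what is new or still open speak of the compounds shown alone.

Series notes. In a functional assay on MCF7 cells (Homo sapiens) for inhibition, read by CCK-8 assay, with a stated time of 48 h (on this read-out lower numbers stand for stronger inhibition and higher numbers for weaker inhibition), compound 2 `O=C(NC(=S)Nc1ccc(Cl)cc1)c1cn(-c2ccccc2)nc1-c1ccccc1` gives 6230 nM. Going by the values given here, compound 1 `O=C(NC(=S)Nc1ccc(F)cc1)c1cn(-c2ccccc2)nc1-c1ccc(F)cc1` in this assay gives 5610 nM; the two figures lie within the usual scatter of each other, so compound 2 stands level with the only other measured compound. Compound 3 `O=C(NC(=S)Nc1ccc(Cl)cc1)c1cn(-c2ccccc2)nc1-c1ccc(F)cc1` is not yet measured; it differs from compound 2 by fluoro in place of hydrogen on an aromatic carbon, on an aromatic carbon of a six-membered aromatic ring of carbon only. Among the compounds with values here, no single-change step has been measured in this set, so this change is expected to bring no step beyond the scatter: a 1.1-fold lower number from compound 2 to compound 3 (0.03 log units; within the scatter). Compound 3 is estimated at 5800 nM in this assay, with a range from 2900 nM to 11600 nM.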

Compound 3, half-maximal inhibitory concentration: 5470 nM
Beside the measured number, compound 3's estimate is 1.1-fold (0.03 log units) above it; measured number inside the range.
By their numbers in this assay, from the lowest: compounds 3, 1 and 2 (each within the scatter of the next).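

Phenyl to 4-fluorophenyl gives a 1.1-fold lower number from compound 2 to compound 3 (0.06 log units; within the scatter) in this assay, the first single-change reading at this position, and it lies within the scatter. Chloro in place of fluoro on an aromatic carbon gives a 1.0-fold lower number from compound 1 to compound 3 (0.01 log units; within the scatter) and also lies within the scatter, so neither change separates these compounds. No supporting data bear on these results. As far as these compounds go, whether an amine, a carboxylic acid or a methoxy group at the position para to a large group would give a step beyond the scatter remains open.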